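Smaller groups on the aromatic nitrogen: towards compound 4

The compounds below may be only part of what the source reports. "The series", "measured", "known", "first", "only" and "open" are said of these compounds alone.

Measured in an assay on isolated protein for inhibition of tyrosine-protein kinase receptor UFO (Homo sapiens), read by ELISA; on this read-out lower numbers stand for stronger inhibition and higher numbers for weaker inhibition:
Compound 1 `Cn1cc(-c2ccc(NC(=O)c3cn(CC4CCCCC4)cc(-c4ccc(F)cc4)c3=O)cc2)c2c(N)ncnc21`: 2.3 nM
Compound 2 `Cn1cc(-c2ccc(NC(=O)c3cn(CC4CCCO4)cc(-c4ccc(F)cc4)c3=O)cc2)c2c(N)ncnc21`: 1.2 nM
Compound 3 `CC(C)n1cc(C(=O)Nc2ccc(-c3cn(C)c4ncnc(N)c34)cc2)c(=O)c(-c2ccc(F)cc2)c1`: 0.4 nM

Compound 3 stands lowest of the three; both steps towards it, a 5.8-fold lower number from compound 1 to compound 3 (0.76 log units; beyond the scatter) and a 3.0-fold lower number from compound 2 to compound 3 (0.48 log units; beyond the scatter), lie beyond the scatter, whereas a 1.9-fold lower number from compound 1 to compound 2 (0.28 log units; within the scatter) does not.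

Compound 4 `Cn1cc(C(=O)Nc2ccc(-c3cn(C)c4ncnc(N)c34)cc2)c(=O)c(-c2ccc(F)cc2)c1` carries methyl in place of isopropyl on an aromatic nitrogen. Among the measured compounds shown here, the steps that bear on this are the same two, a 5.8-fold lower number from compound 1 to compound 3 (0.76 log units; beyond the scatter) and a 3.0-fold lower number from compound 2 to compound 3 (0.48 log units; beyond the scatter): each replaces a larger group on that nitrogen by isopropyl and each lowers the number. For the measured compounds named here, no measured pair shows whether a further cut to methyl continues this, and the two steps differ in size. The step expected here is a 1.3-fold higher number from compound 3 to compound 4 (0.10 log units; within the scatter), within the scatter. Compound 4 is estimated at 0.5 nM, range 0.2 nM to 1.5 nM.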

Compound 4, half-maximal inhibitory concentration: 5 nM
The estimate for compound 4 lay 10-fold (1.00 log units) below the measured number; measured number above the stated range.
By their numbers in this assay, from the lowest: compound 3; then compounds 2 and 1 (each within the scatter of the next); then compound 4.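

Shortening the group on this aromatic nitrogen does not keep lowering the number: methyl in place of isopropyl gives a 13-fold higher number from compound 3 to compound 4 (1.10 log units; beyond the scatter), so the fall seen on going to isopropyl reverses at methyl. Compound 4 also stands above both compounds with larger groups, with a 4.2-fold higher number from compound 2 to compound 4 (0.62 log units; beyond the scatter) and a 2.2-fold higher number from compound 1 to compound 4 (0.34 log units; beyond the scatter), so among these four the lowest number falls at isopropyl, not at either extreme of size. Nothing at hand accounts for this reversal.

Open, on these data alone, is how ethyl or cyclopropyl would fall between methyl and isopropyl. Also open, as far as these compounds go, is whether a chain ending in an amine would be tolerated on this nitrogen.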